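Oxan-2-yl in place of 6-hydroxyhexyl on the sulfonyl chain

This account rests on a few compounds, and the source may have more. Where it says the series, first, only, none or still open, it means among the compounds named here.

In a functional assay, read by fluorescence and spectrophotometry, with a stated time of 1 h (on this read-out higher numbers stand for an effect only at larger amounts of compound and lower numbers for an effect already at smaller amounts), compound 1 `O=S(=O)(/C=C/c1ccc(O)c(O)c1)CC1CC1` gives 10500 nM and compound 2 `O=S(=O)(/C=C/c1ccc(O)c(O)c1)CC1CCCN1` gives 13800 nM while compound 3 `O=S(=O)(/C=C/c1ccc(O)c(O)c1)CCCCCCCO` gives 5900 nM on the shared core. Compound 3 lies within the scatter of compound 1 (a 1.8-fold lower number from compound 1 to compound 3 (0.25 log units; within the scatter)) but beyond it from compound 2 (a 2.3-fold lower number from compound 2 to compound 3 (0.37 log units; beyond the scatter)). Compound 4 `O=S(=O)(/C=C/c1ccc(O)c(O)c1)CC1CCCCO1` remains unmeasured; it differs from compound 3 as follows: oxan-2-yl in place of 6-hydroxyhexyl on a saturated chain carbon bound to a sulfonyl sulfur (oxan-2-yl in place of 6-hydroxyhexyl). Within the data shown here, exchanging cyclopropyl for pyrrolidin-2-yl stayed within the scatter (a 1.3-fold higher number from compound 1 to compound 2 (0.12 log units; within the scatter)) and no oxan-2-yl compound has a measured value, so compound 4 is expected to sit with compound 1 and compound 2. The estimated step in this assay is a 1.7-fold higher number from compound 3 to compound 4 (0.23 log units; within the scatter) with a higher number expected. Compound 4 is estimated at 10000 nM (expected range 5000 nM to 20000 nM).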

Compound 4, half-maximal effective concentration: 10800 nM
For compound 4 the middle estimate is 1.1-fold (0.03 log units) below the measured one, and the stated range covers the measured number.
By their numbers in this assay, from the lowest: compounds 3, 1, 4 and 2 (each within the scatter of the next, the first and the last beyond it).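

In this assay the oxan-2-yl group cannot be told apart from any of the three other groups at this place (a 1.8-fold higher number from compound 3 to compound 4 (0.26 log units; within the scatter); a 1.3-fold lower number from compound 2 to compound 4 (0.11 log units; within the scatter); a 1.0-fold higher number from compound 1 to compound 4 (0.01 log units; within the scatter)). Compound 4 carries a six-membered ring and no hydrogen-bond donor, and compound 3 carries an open chain with one, so at this place neither difference takes the number beyond the scatter. No measurement at hand explains this result.

Cyclohexyl, with no oxygen in its ring, would test whether the ring oxygen of oxan-2-yl matters here. On these data alone, whether a carboxylic acid or a longer chain at this place would give a step beyond the scatter stays open.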